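This account rests on a few compounds, and the source may have more. Where it says the series, first, only, none or still open, it means among the compounds named here.

In an ADME assay on microsomes from liver (Canis lupus familiaris) for metabolic stability (on this read-out lower numbers stand for a shorter-lived compound and higher numbers for a longer-lived compound), compound 1 (`Nc1nc(NCCNc2ncc(-c3ncc[nH]3)c(-c3ccc(F)cc3Br)n2)ccc1[N+](=O)[O-]`) reads > 0.5 h as a limit of the assay and not a number. Compound 2 (`Nc1nc(NCCNc2ncc(-c3ncc[nH]3)c(-c3ccc(F)cc3C(F)(F)F)n2)ccc1[N+](=O)[O-]`) reads > 0.5 h as a limit too. Compound 3 (`Nc1nc(NCCNc2ncc(-c3ncc[nH]3)c(-c3ccc(Cl)cc3F)n2)ccc1[N+](=O)[O-]`) reads > 0.5 h as a limit as well, so it offers no number to start from. The whole set comes down to the limit of > 0.5 h in this assay, at which 3 of the 3 values shown sit, and nothing finer.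

Compound 4 (`Nc1nc(NCCNc2ncc(-c3ncc[nH]3)c(-c3cc(F)c(Cl)cc3Cl)n2)ccc1[N+](=O)[O-]`) is not yet measured. It carries 2,4-dichloro-5-fluorophenyl in place of 4-chloro-2-fluorophenyl on an aromatic carbon and keeps the shared core. Among the compounds with values here, the closest precedents are changes at the same place: a step that the two limits leave unreadable from compound 1 to compound 3 and a step that the two limits leave unreadable from compound 2 to compound 3 together with a step that the two limits leave unreadable from compound 1 to compound 2 are the only steps available. None of them has a size, so neither a size nor a direction can be carried over to the new change in this assay as a guide.

No shift beyond the scatter is expected, and the estimated step is a step that the limit leaves unreadable from compound 3 to compound 4 with no preferred direction. Compound 4 is expected to report a limit too, in line with the limit of > 0.5 h in this assay, at which 3 of the 3 values shown sit, and without a readable number. The estimate for compound 4 is 0.8 h with 0.4 h and 2 h as the expected ends of its range.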

Compound 4, half-life: > 0.5 h
Compound 4: only a limit was reported; the forecaster's own chance of this, stated with the estimate: 75%; the middle value does not contradict the limit.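

In this assay compound 4 gives > 0.5 h, a limit of the assay and not a number. Within the data shown here, no step from compound 1, compound 2 or compound 3 to compound 4 can be read, and the set offers only one shared limit: the limit of > 0.5 h in this assay, at which 4 of the 4 values shown sit. The compounds shown leave open the actual half-life of each compound and whether exchanging these substituted phenyl groups on the shared core changes it at all.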